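Chloro for bromo at the assay limit

The compounds below may be only part of what the source reports. "The series", "measured", "known", "first", "only" and "open" are said of these compounds alone.

In a functional assay on HepG2 cells (Homo sapiens) for antiproliferative activity, read by CCK-8 assay, with a stated time of 72 h (a lower number here means a stronger inhibitor, a higher number a weaker inhibitor), compound 1 `Nc1ccccc1NC(=O)c1ccc(COc2ccc([N+](=O)[O-])cc2)cc1` reads > 32000 nM, which is a limit of the assay and not a number. Compound 2 `Nc1ccccc1NC(=O)c1ccc(COc2ccc(Br)cc2)cc1` reads > 32000 nM, which is also a limit. Compound 2 therefore stands at the limit of > 32000 nM in this assay, at which 2 of the 3 values shown sit. Going by the values given here, compound 3 `O=C(/C=C/c1ccc(CN2CCc3ccccc32)cc1)NO` gives 14900 nM, the only true number so far.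

Compound 4 `Nc1ccccc1NC(=O)c1ccc(COc2ccc(Cl)cc2)cc1` changes compound 2 in one place: chloro in place of bromo on an aromatic carbon. This is chloro in place of bromo on an aromatic carbon, para to a large group, so that 4-bromophenoxy becomes 4-chlorophenoxy.

Among the compounds with values here, the one measured step that bears on this change is a step that the two limits leave unreadable from compound 1 to compound 2, with bromo in place of nitro on an aromatic carbon. Both ends of that step are limits, so it offers no size and no direction to carry over. No step beyond the scatter is therefore expected in this assay, and no direction is favoured. The expected step is a step that the limit leaves unreadable from compound 2 to compound 4. A report of compound 4 as another limit is the more likely outcome. If a number is obtained, the estimate for compound 4 is 36000 nM, with an expected range of 20000 nM to 64000 nM.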

Compound 4, half-maximal inhibitory concentration: > 32000 nM
Compound 4 gave a limit, no number (the forecaster's own chance of this, stated with the estimate: 80%); the middle value lies beyond the limit too.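

In this assay compound 4 gives > 32000 nM, a limit of the assay and not a number. Compound 2 gives > 32000 nM, also a limit. No new step can be read among compound 1, compound 2 and compound 4. Whether nitro, bromo and chloro on the shared core differ at all in this assay stays open, as the series mostly rests at one limit: the limit of > 32000 nM in this assay, at which 3 of the 4 values shown sit.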